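This account rests on a few compounds, and the source may have more. Where it says the series, first, only, none or still open, it means among the compounds named here.

Measured compounds and their values:
- compound 1 `C/C(C(=O)NC1CC1)=C(\C)c1ccc(Br)cc1`: 450 mg/kg
- compound 2 `C=CCNC(=O)/C(C)=C(\C)c1cc(OC)c(OC)c(OC)c1`: 280 mg/kg
- compound 3 `C#CCNC(=O)/C(C)=C(\C)c1ccc(Cl)cc1`: 400 mg/kg

The read-out throughout is a toxicity assay on the whole organism (strain Icem-CET (SPF Caw)) for cytotoxicity, with Mus musculus as the target; on this read-out lower numbers stand for an effect already at smaller amounts and higher numbers for an effect only at larger amounts of compound. Within this small set compound 3 stands second highest of three numbers. Its nearest neighbour is compound 1, whose value lies within the usual scatter of that of compound 3; the furthest is compound 2, and this gap too lies within the scatter. None of the three compounds can therefore be set apart from the others on this assay: the bromo, trimethoxy and chloro variants of the shared core, with their differing amide substituents, all return numbers of the same order.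

Compound 4 `C#CCNC(=O)/C(C)=C(\C)c1ccc(C)cc1` remains to be measured. It differs from compound 3 in one place: methyl in place of chloro on an aromatic carbon. Among the compounds with values here, no step between measured compounds is available to gauge this exchange, and the whole series so far shows no spread beyond the scatter. The step from compound 3 to compound 4 is thus expected to be small, no change at the digits printed from compound 3 to compound 4 (within the scatter), in no preferred direction. Compound 4 is estimated at 400 mg/kg, with a range of 200 mg/kg to 800 mg/kg.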

Compound 4, dose for half-maximal effect: 200 mg/kg
Estimate against measurement, compound 4: 2.0-fold (0.30 log units) above; the range from low to high includes it.
By their numbers in this assay, from the lowest: compounds 4, 2, 3 and 1 (each within the scatter of the next, the first and the last beyond it).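

In this assay, within the data shown here, the exchange of methyl in place of chloro on an aromatic carbon, para to a large group, gives a 2.0-fold lower number from compound 3 to compound 4 (0.30 log units; within the scatter) and so provides the first single-place comparison. At this position, one heavy atom for another, with no hydrogen-bond donors or acceptors on either side, does not set the two compounds apart. Nothing at hand speaks to the origin of this step.

From the compounds shown here alone, whether an amine, a carboxylic acid or a longer chain on this aromatic carbon would give a step beyond the scatter remains open. Also open, going by these compounds, is whether methyl in place of chloro reads the same with a different amide substituent, such as the cyclopropyl amide of compound 1.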